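Chloro for Methyl on Two Oxadiazole Sulfonamide Cores

This account rests on a few compounds, and the source may have more. Where it says the series, first, only, none or still open, it means among the compounds named here.

Compound 1 `Cc1ccc(-c2nnc(-c3cccc(S(N)(=O)=O)c3)o2)cc1`: in an assay on cells for inhibition of Amine oxidase [flavin-containing] A (Homo sapiens), read by fluorescence and spectrophotometry, using microsomes, with a stated time of 20 min (on this read-out higher numbers stand for weaker inhibition and lower numbers for stronger inhibition), compound 1 gives 61400 nM.
Compound 2 `NS(=O)(=O)c1cccc(-c2nnc(-c3ccc(Cl)cc3)o2)c1`: compound 2 gives only a limit, > 100000 nM.
Compound 3 `Cc1ccc(-c2nnc(-c3ccccc3)o2)cc1S(N)(=O)=O`: compound 3 likewise gives only a limit, > 100000 nM.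

From compound 1 to compound 2 the change is chloro in place of methyl on an aromatic carbon, and it gave an at least 1.6-fold higher number from compound 1 to compound 2 (0.21 log units; that floor lies within the scatter). Compound 4 `NS(=O)(=O)c1cc(-c2nnc(-c3ccccc3)o2)ccc1Cl` carries the same kind of change relative to compound 3, (chloro in place of methyl on an aromatic carbon), but here the place is also ortho to a sulfamoyl group, so it is not the same change. The difference between the two cores is not broken down here.

Compound 4 is expected to sit at the limit of > 100000 nM in this assay, at which 2 of the 3 values shown sit, as well, because compound 2 and compound 3 both sit at the limit of > 100000 nM in this assay, at which 2 of the 3 values shown sit. The expected step is a step that the limit leaves unreadable from compound 3 to compound 4. Compound 4 is estimated at 150000 nM, with a range from 60000 nM to 400000 nM.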

Compound 4, half-maximal inhibitory concentration: > 100000 nM
Compound 4 gave a limit, no number (the forecaster's own chance of this, stated with the estimate: 75%); the middle value does not contradict the limit.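

Compound 4 gives only a limit, > 100000 nM. Compound 3 also gives only a limit, > 100000 nM, so no step can be read between these two compounds. The compounds shown leave open how chloro in place of methyl acts on this core.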